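The source may report more compounds than this note shows. Statements on the series, on what has been measured and on what is new or still open speak of the compounds shown alone.

Compound 1 `Cc1nn(C)c(Oc2ccccc2F)c1/C=N\CCCCCCOc1cc2oc(=O)cc(C)c2cc1Cl` gives in a functional assay on SMMC-7721 cells (Homo sapiens) for antiproliferative activity, read by MTT assay, with a stated time of 72 h (on this read-out lower numbers stand for stronger inhibition and higher numbers for weaker inhibition), only a limit of the assay, > 25000 nM.
Compound 2 `Cc1nn(C)c(Oc2cccc(F)c2F)c1/C=N\CCCCCCOc1cc2oc(=O)cc(C)c2cc1Cl` gives in this assay 22800 nM.
Compound 3 `Cc1nn(C)c(Oc2ccc(F)cc2F)c1/C=N\CCCCCCOc1cc2oc(=O)cc(C)c2cc1Cl` gives in this assay only a limit of the assay, > 25000 nM.

Compound 3 thus stands at the limit, where two of the three values sit (the limit of > 25000 nM in this assay, at which 2 of the 3 values shown sit), and compound 2 sits close to it. The two measured steps that can be read are both small: an at least 1.0-fold lower number from compound 1 to compound 2 (0.04 log units; that floor lies within the scatter) and an at least 1.0-fold higher number from compound 2 to compound 3 (0.04 log units; that floor lies within the scatter), each within the scatter. The step that the two limits leave unreadable from compound 1 to compound 3 cannot be read, as both ends are limits.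

Compound 4 `Cc1nn(C)c(Oc2cccc(Cl)c2)c1/C=N\CCCCCCOc1cc2oc(=O)cc(C)c2cc1Cl` differs from compound 3 in that (3-chlorophenyl in place of 2,4-difluorophenyl on an oxygen on an aromatic ring). Among the measured compounds shown here, no measured step changes the phenoxy group in the same way; the steps that bear on this position, from compound 1 through compound 2 to compound 3, only vary fluorine on the phenyl ring and all stay within the scatter, with every value at or beside the limit. The account therefore expects no step beyond the scatter in this assay and expects a number no higher from compound 3 to compound 4 (the limit leaves the size open) for compound 4. Compound 4 is estimated at 25000 nM, between 12000 nM and 60000 nM, most likely reported again only as a limit.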

Compound 4, half-maximal inhibitory concentration: 5260 nM
The estimate for compound 4 lay 4.8-fold (0.68 log units) above the measured number; measured number below the stated range.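

In this assay, among the compounds shown here, the group on this oxygen can move the number beyond the scatter, which the fluorine variations among the earlier compounds did not show: 3-chlorophenyl in place of 2,4-difluorophenyl gives an at least 4.7-fold lower number from compound 3 to compound 4 (0.67 log units; beyond the scatter), and the corresponding replacements give a 4.3-fold lower number from compound 2 to compound 4 (0.64 log units; beyond the scatter) and an at least 4.7-fold lower number from compound 1 to compound 4 (0.67 log units; beyond the scatter). For the compounds shown here, only the step that starts from compound 2 has a measured number at both ends, while the other two give only a floor for their size, as compound 1 and compound 3 each stand at a limit of the assay: the limit of > 25000 nM in this assay, at which 2 of the 4 values shown sit. The change to compound 4 swaps fluorine for chlorine, alters where the halogen sits and leaves one halogen on the ring instead of two, so these three compounds cannot assign the step to any one of these features.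

Going by these compounds, whether a 3-fluorophenyl, a 4-chlorophenyl or a 3-bromophenyl group on the same oxygen would give a number like that of compound 4 stays open. Going by these compounds alone, also open is whether the step from the 3-chlorophenyl group would hold with a shorter chain in place of the one shared by these compounds.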